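Chloro Added to the Aryl Thiourea of Compound 3

The compounds below may be only part of what the source reports. "The series", "measured", "known", "first", "only" and "open" are said of these compounds alone.

In a functional assay on MDA-MB-231 cells (Homo sapiens) for cytotoxicity, read by MTT assay, with a stated time of 48 h (on this read-out lower numbers stand for stronger inhibition and higher numbers for weaker inhibition), compound 3 `O=C(c1cc(Oc2cccc(NC(=S)Nc3cccc(C(F)(F)F)c3)c2)ccn1)N1CCCC1` gives 35400 nM, the lowest of the two plain numbers recorded. The nearest is compound 2 `CCNC(=O)c1cc(Oc2cccc(NC(=S)Nc3cccc(C(F)(F)F)c3)c2)ccn1` with 53100 nM, and the gap, a 1.5-fold lower number from compound 2 to compound 3 (0.18 log units; within the scatter), is too small to count as a real change. Compound 1 `O=C(c1cc(Oc2cccc(NC(=S)Nc3ccc(F)c(F)c3)c2)ccn1)N1CCCC1` gives no number but a limit of the assay, > 100000 nM. Of the three results, one sits at the limit of > 100000 nM in this assay, at which 1 of the 3 values shown sits. For the measured compounds named here, the change on the aryl thiourea side, an at least 2.8-fold lower number from compound 1 to compound 3 (0.45 log units; beyond the scatter), is the only measured step of real size. Compound 4 `O=C(c1cc(Oc2cccc(NC(=S)Nc3ccc(Cl)c(C(F)(F)F)c3)c2)ccn1)N1CCCC1` differs from compound 3 by chloro in place of hydrogen on an aromatic carbon. Going by the values given here, no measured step adds a single substituent to this ring while leaving the rest in place: the one that touches the ring rebuilt its whole substitution pattern, and the other altered the amide end. The expectation is therefore a step near the scatter, leaning toward a lower number: a 1.4-fold lower number from compound 3 to compound 4 (0.15 log units; within the scatter). Compound 4 is estimated at 25000 nM, with a likely range from 8000 nM to 80000 nM.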

Compound 4, half-maximal inhibitory concentration: 40200 nM
Beside the measured number, compound 4's estimate is 1.6-fold (0.21 log units) below it, and the stated range covers the measured number.
By their numbers in this assay, from the lowest: compounds 3, 4 and 2 (each within the scatter of the next). At a limit, above all of these: compound 1.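

In this assay, for the compounds shown here, this is the first step that adds a single substituent to the ring and leaves the rest in place, and chloro ortho to the trifluoromethyl group gives a result within the scatter: a 1.1-fold higher number from compound 3 to compound 4 (0.06 log units; within the scatter). At this position, then, chloro brings no difference that the read-out can separate from the spread of repeated measurements. The step from the 3,4-difluorophenyl ring stays beyond the scatter with chloro present, an at least 2.4-fold lower number from compound 1 to compound 4 (0.39 log units; beyond the scatter), but its starting value is a limit and not a number: the limit of > 100000 nM in this assay, at which 1 of the 4 values shown sits.

The compounds shown leave open whether another group at this position, such as a methoxy group, an amine or a carboxylic acid, would move the number beyond the scatter. They also leave open whether chloro would read the same with the ethylamino amide of compound 2 in place of the pyrrolidin-1-yl amide.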